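The source may hold more compounds than are shown below. What is called first, only, known or untested is meant among the compounds shown, and "the series" means these compounds.

Measured so far:
- compound 1 `CCCCOc1cccc2ccc(N)nc12` gives 789 nM in an assay on cells with melanin-concentrating hormone receptor 1 (Homo sapiens) as the target, read by radioligand binding; a higher number here means a weaker inhibitor, a lower number a stronger inhibitor
- compound 2 `Nc1ccc2cccc(OCC3CCC3)c2n1` gives 432 nM in this assay
- compound 3 `CC(C)C(C)Oc1cccc2ccc(N)nc12` gives 199 nM in this assay

Compound 3 stands lowest of the three; its nearest neighbour is compound 2 and its furthest is compound 1, both of those gaps being beyond the scatter. The step in question goes to compound 4 `CC(C)(C)CCOc1cccc2ccc(N)nc12`, with the change (3,3-dimethylbutyl in place of 1,2-dimethylpropyl on an oxygen on an aromatic ring). Within the data shown here, two measured steps touch the same oxygen: a 4.0-fold lower number from compound 1 to compound 3 (0.60 log units; beyond the scatter) and a 2.2-fold lower number from compound 2 to compound 3 (0.34 log units; beyond the scatter), both ending at compound 3 and both pointing to lower numbers as the chain on the oxygen is enlarged and branched. Compound 4 keeps a branched chain and adds one carbon, but the branching moves to the far end of the chain, a pattern not represented among the measured compounds. The expectation is therefore a step of roughly a 1.3-fold higher number from compound 3 to compound 4 (0.10 log units; within the scatter), that is within the scatter, with no firm direction. Compound 4 is expected to give about 250 nM in this assay, estimated between 100 nM and 650 nM.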

Compound 4, half-maximal inhibitory concentration: 201 nM
Beside the measured number, compound 4's estimate is 1.2-fold (0.09 log units) above it, within the range that was stated.
By their numbers in this assay, from the lowest: compounds 3 and 4 (each within the scatter of the next); then compounds 2 and 1 (each within the scatter of the next).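

The 3,3-dimethylbutyl and 1,2-dimethylpropyl chains on the oxygen cannot be told apart in this assay, with a 1.0-fold higher number from compound 3 to compound 4 (0.00 log units; within the scatter), so two differently branched chains of different size serve equally well at this place. The 3,3-dimethylbutyl chain also shares the advantage that the 1,2-dimethylpropyl chain showed over the other two chains, with a 2.1-fold lower number from compound 2 to compound 4 (0.33 log units; beyond the scatter) and a 3.9-fold lower number from compound 1 to compound 4 (0.59 log units; beyond the scatter), both beyond the scatter. No evidence is available that accounts for these results.

On these data alone, it remains open whether a chain longer than 3,3-dimethylbutyl on the oxygen would keep numbers of this size, or whether they would rise. Also open, as far as these compounds go, is how a phenyl ring, an amine or a carboxylic acid in the group on the oxygen would read in this assay.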